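The compounds below may be only part of what the source reports. "The series", "measured", "known", "first", "only" and "open" are said of these compounds alone.

Three compounds with a shared core come first: compound 1 `N[C@H]1CC[C@H](Nc2c(C(=O)NCc3ccc(Oc4ccccc4)cc3)nc(Br)c3cccnc23)CC1`, compound 2 `Nc1ccc(Nc2c(C(=O)NCc3ccc(F)cc3)nc(Br)c3cccnc23)cc1` and compound 3 `N[C@H]1CC[C@H](Nc2c(C(=O)NCc3ccc(Cl)cc3Cl)nc(Br)c3cccnc23)CC1`. In a functional assay on HCT-116 cells (Homo sapiens) for cytotoxicity, read by MTT assay, with a stated time of 72 h (a lower number here means a stronger inhibitor, a higher number a weaker inhibitor), the result for compound 1 is "not determined" (no result reported). In this assay, compound 2 gives 10000 nM and compound 3 gives 6000 nM. Going by the values given here, these two values lie within the scatter of each other, so compound 2 cannot be set apart from the only other number available. Compound 4 `NCCNc1c(C(=O)NCc2ccc(F)cc2)nc(Br)c2cccnc12` differs from compound 2 in one place: 2-aminoethyl in place of 4-aminophenyl on a nitrogen on an aromatic ring. Among the compounds with values here, no measured step between compounds differing in one place guides this change, so no shift beyond the scatter is expected in this assay. The estimated step is a 1.7-fold lower number from compound 2 to compound 4 (0.22 log units; within the scatter). For compound 4 the estimate is 6000 nM, with an expected range from 2000 nM to 20000 nM.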

Compound 4, half-maximal inhibitory concentration: > 20000 nM
Compound 4 ended at the assay's limit (the forecaster's own chance of this, stated with the estimate: 20%); at least 3.3-fold (0.52 log units) between middle value and limit.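

In this assay compound 4 gives > 20000 nM, which is a limit of the assay and not a number. This supplies the only step shown at this position, with 2-aminoethyl in place of 4-aminophenyl on a nitrogen on an aromatic ring: an at least 2.0-fold higher number from compound 2 to compound 4 (0.30 log units; that floor lies within the scatter). The change gave no stronger inhibitor, but the floor of the step does not establish a shift beyond the scatter, and its true size cannot be read from a limit. The compounds shown leave open how a longer chain ending in an amine, such as 3-aminopropyl, or a carboxylic acid would read on this nitrogen.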